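The source may hold more compounds than are shown below. What is called first, only, known or untested is meant among the compounds shown, and "the series" means these compounds.

Compound 2 `O=C(O)CCCSCCN1C(=O)SC[C@@H]1/C=C/[C@@H](O)Cc1ccccc1` and compound 1 `CCc1cccc(C[C@H](O)/C=C/[C@H]2COC(=O)N2CCSCCCC(=O)O)c1` are the two compounds for which numbers exist in an assay on CHO cells for displacement of a labelled ligand from prostaglandin E2 receptor EP3 subtype (Mus musculus), read by scintillation counting, with a stated time of 60 min; on this read-out lower numbers stand for stronger inhibition and higher numbers for weaker inhibition. In this assay compound 2 gives 39 nM, the lowest of the two numbers; in this assay compound 1 gives 2700 nM, a gap to compound 2 that lies well beyond the scatter. The two compounds differ in more than one place, so the gap cannot be tied to a single change; only the two values themselves are known.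

Compound 3 `O=C(O)CCCSCCN1C(=O)SC[C@@H]1/C=C/[C@@H](O)Cc1cccc(C(F)(F)F)c1` is not yet measured in this assay. It differs from compound 2 in one way: trifluoromethyl in place of hydrogen on an aromatic carbon. The change sits on an aromatic carbon of a six-membered aromatic ring of carbon only, meta to a large group, so that the phenyl becomes a 3-(trifluoromethyl)phenyl.

For the measured compounds named here, no measured pair isolates this change, so its effect is unknown. Compound 3 is expected to stay close to compound 2, with a step of a 1.5-fold higher number from compound 2 to compound 3 (0.19 log units; within the scatter) that may lie within the scatter or amount to a modest loss. Compound 3 is estimated at 60 nM, with a likely range from 15 nM to 250 nM.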

Compound 3, inhibition constant: 280 nM
Compound 3: middle estimate off by 4.7-fold (0.67 log units), on the low side; the measured number lies above the stated range.
By their numbers in this assay, from the lowest: compound 2; then compound 3; then compound 1.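

For the compounds shown here, this step is the first to isolate a single change, so this assay can now be read for one position on the phenyl ring. Trifluoromethyl in place of hydrogen on this aromatic carbon, meta to a large group, gives a 7.2-fold higher number from compound 2 to compound 3 (0.86 log units; beyond the scatter), so the change is a real loss on this read-out rather than a neutral swap. Compound 3 still gives 280 nM, which shows that the 3-(trifluoromethyl)phenyl compound keeps measurable binding in this assay despite the added bulk of four heavy atoms, although nothing measured here explains why the number rises.

The compounds shown leave open whether a smaller group on the same aromatic carbon, such as a methyl group or a single chlorine atom, would bring a step of similar size or none at all. They also leave open whether trifluoromethyl on another carbon of this ring would read the same way, and whether the change would carry over to the core of compound 1, whose ring holds an ethyl group.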